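A few compounds are considered here, and "the series" means these few. Any claim that something is new, unique, unknown or untested is made for them only; others in the source may bear on it.

Compound 1 `O=C(Nc1nc(-c2ccccc2Cl)cs1)c1ccccc1`: 15000 nM
Compound 2 `COc1cc(-c2csc(NC(=O)c3ccc(Cl)cc3)n2)cc(OC)c1OC`: > 25000 nM (a limit)
Compound 3 `COc1cc(-c2cs/c(=N\C(=O)c3ccccc3)n2C)cc(OC)c1OC`: 1070 nM

All three compounds were tested in a functional assay on MDA-MB-231 cells (Homo sapiens), read by microscopy and transwell migration, with a stated time of 24 h; a lower number here means a stronger inhibitor, a higher number a weaker inhibitor. Compound 3 gives the lowest number, 1070 nM. The nearest number belongs to compound 1, at 15000 nM, and the gap between the two lies beyond the usual scatter. The reading for compound 2, > 25000 nM, is a limit of the assay and not a number.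

The next compound is compound 4 `COc1cccc(C(=O)/N=c2\scc(-c3cc(OC)c(OC)c(OC)c3)n2C)c1`, which differs from compound 3 in one place: methoxy in place of hydrogen on an aromatic carbon. In words, a methoxy stands in place of a hydrogen on an aromatic carbon, turning phenyl into 3-methoxyphenyl. For the measured compounds named here, no pair of measured compounds differs in one place, so the data give no direct guide to the size of this change. The expected step in this assay, a 1.1-fold higher number from compound 3 to compound 4 (0.05 log units; within the scatter), is estimated to stay within the usual scatter, with neither direction favoured. For compound 4 the expected value is 1200 nM, with an estimated range of 350 nM to 5000 nM.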

Compound 4, half-maximal inhibitory concentration: > 50000 nM
Compound 4 was reported as a limit (the forecaster's own chance of this, stated with the estimate: 8%); at least 41-fold (1.61 log units) between middle value and limit.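

In this assay, adding one methoxy to the phenyl of compound 3 gives a large loss, with an at least 46-fold higher number from compound 3 to compound 4 (1.66 log units; beyond the scatter). This is the first pair shown that differs in one place, and it shows that the change to 3-methoxyphenyl, on a carbon meta to a large group, does not leave the activity of compound 3 intact. The reading for compound 4 is a limit and not a number, so the true size of the step stays unknown: the limit of > 50000 nM in this assay, at which 1 of the 4 values shown sits.

The compounds shown give no reason for this loss, and they cannot separate the effect of the methoxy itself from the effect of its place on the ring. Going by these compounds, what a fluorine, a methyl or a hydroxyl would do on this same carbon stays open, as does a methoxy on another carbon of this ring.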